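The compounds below may be only part of what the source reports. "The series", "measured", "known", "first", "only" and "open" are said of these compounds alone.

In a functional assay on HepG2 cells (Homo sapiens) for cytotoxicity, read by MTT assay, with a stated time of 72 h (on this read-out lower numbers stand for stronger inhibition and higher numbers for weaker inhibition), two compounds sharing one core have been measured so far. Compound 1 (`O=C(N/N=C/c1ccc(F)cc1Cl)Nc1cc2c(Nc3ccc(F)c(Cl)c3)ncnc2cc1O[C@H]1CCOC1`), with a 2-chloro-4-fluorophenyl group on a carbon with a double bond to nitrogen, gives 26100 nM. Compound 2 (`O=C(N/N=C/c1ccc(O)c(Br)c1)Nc1cc2c(Nc3ccc(F)c(Cl)c3)ncnc2cc1O[C@H]1CCOC1`), with a 3-bromo-4-hydroxyphenyl group in that place, gives 660 nM, the lower of the two numbers. Going by the values given here, the only measured step, a 40-fold lower number from compound 1 to compound 2 (1.60 log units; beyond the scatter), is large and beyond the scatter, but it exchanges one whole substituted phenyl group for another, so it bears only loosely on what follows.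

Compound 3 (`O=C(N/N=C/c1cc(Br)c(O)c(Br)c1)Nc1cc2c(Nc3ccc(F)c(Cl)c3)ncnc2cc1O[C@H]1CCOC1`) departs from compound 2 by a single change: bromo in place of hydrogen on an aromatic carbon. This is bromo in place of hydrogen on an aromatic carbon, turning 3-bromo-4-hydroxyphenyl into 3,5-dibromo-4-hydroxyphenyl. Among the compounds with values here, no measured step isolates such a change, and the hydroxy group and the first bromo of compound 2 remain, so no step beyond the scatter is expected in this assay. The expected step is a 1.2-fold higher number from compound 2 to compound 3 (0.08 log units; within the scatter). Compound 3 is estimated at 800 nM, with an expected range from 180 nM to 3500 nM.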

Compound 3, half-maximal inhibitory concentration: 2740 nM
Compound 3: the middle estimate sits 3.4-fold (0.53 log units) below what was measured; the range from low to high includes it.
By their numbers in this assay, from the lowest: compound 2; then compound 3; then compound 1.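

The position ortho to the hydroxy group is not indifferent in this assay: a single added bromo gives a 4.2-fold higher number from compound 2 to compound 3 (0.62 log units; beyond the scatter) and so moves the read-out towards weaker inhibition, something the earlier whole-group exchange could not show for this one position. The second bromo does not cancel the earlier difference between the aryl groups, since the step of a 9.5-fold lower number from compound 1 to compound 3 (0.98 log units; beyond the scatter) still favours the 3,5-dibromo-4-hydroxyphenyl group over the 2-chloro-4-fluorophenyl group, though by less than the 3-bromo-4-hydroxyphenyl group did. Nothing available accounts for the loss on adding the second bromo, and the compounds give only its size and direction.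

Going by these compounds, it remains open whether this loss belongs to bromo in particular or would also appear with chloro, methyl or methoxy at the same place. The compounds shown also leave unsettled what the first bromo and the hydroxy group each contribute, as neither a plain 4-hydroxyphenyl group nor one carrying an amine in place of the hydroxy group is among them.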